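The compounds below may be only part of what the source reports. "The series", "measured", "known", "first", "only" and "open" are said of these compounds alone.

Measured so far in a functional assay on NCI-H322M cells (Homo sapiens) for inhibition, read by sulforhodamine B assay, with a stated time of 48 h, tested at 10 uM; on this read-out lower numbers stand for less inhibition of growth and higher numbers for more inhibition of growth at the one concentration tested:
Compound 1 (`C/C(=N\O)c1ccc(NC(=O)Cn2nc(-c3ccc(Cl)cc3)nc2N)cc1`): 7.09%
Compound 2 (`COc1ccc(-c2nc3sc(-c4ccccc4)cn3n2)cc1`): 14%
Compound 3 (`COc1cc(-c2nc(N)n(CC(=O)Nc3ccc(/C(C)=N\O)cc3)n2)cc(OC)c1OC`): 5.82%

Compound 2 at 14% lies within the scatter of both compound 1 and compound 3, so these numbers do not separate the three compounds. Compound 4 (`COc1ccc(-c2nc3sc(-c4ccc(Cl)cc4)cn3n2)cc1`) keeps the core of compound 2 and has chloro in place of hydrogen on an aromatic carbon, para to a large group (chloro in place of hydrogen on an aromatic carbon), which turns phenyl to 4-chlorophenyl. Going by the values given here, no two measured compounds differ in one place, so the effect of this change has not been measured directly. The expectation therefore rests on compound 2 at 14% as its starting point, and no change beyond the scatter is expected. An estimated a number 1 percentage points higher from compound 2 to compound 4 (within the scatter) would stay within that scatter. In this assay compound 4 is estimated at 15% with 3% to 32% as the expected range.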

Compound 4, percent growth inhibition at one concentration: 82.2%
Compound 4: middle estimate off by 67.2 percentage points, on the low side; measured number above the stated range.
By their numbers in this assay, from the lowest: compounds 3, 1 and 2 (each within the scatter of the next); then compound 4.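

In this assay, the exchange of phenyl for 4-chlorophenyl gives a number 68.2 percentage points higher from compound 2 to compound 4 (beyond the scatter). The earlier compounds shown here could not separate from one another beyond the scatter, and none of them formed a one-place pair, so they gave no sign of how much this position could matter. This step shows that one chlorine, entering on an aromatic carbon para to a large group, is enough to turn a compound with little growth inhibition at the tested concentration into one with much more, although nothing at hand explains why.

On these data alone, whether fluoro, bromo, methyl or an amine in the same place would give a similar step remains open. As far as these compounds go, it also remains open whether chloro elsewhere on this ring, or the same exchange on another core, would have a comparable effect.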